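From Free Acid to Chlorophenyl Amide

The compounds below may be only part of what the source reports. "The series", "measured", "known", "first", "only" and "open" are said of these compounds alone.

In a functional assay on HO8910 cells (Homo sapiens) for inhibition, read by MTT assay, with a stated time of 24 h, tested at 0.1 ug/mL (a lower number here means less inhibition of growth, a higher number more inhibition of growth at the concentration tested), compound 1 (`CC(=O)SCCC(CCCCC(=O)O)SC(C)=O`) is recorded only as "not active" (no number reported) and so offers no number to start from. Among the compounds with values here, compound 2 (`O=C(CCCCC1CCSS1)Nc1ccc(Br)cn1`) is also "not active" (no number reported) in this series, and compound 3 (`O=C(CCCCC(S)CCS)Nc1cccc(C(F)(F)F)c1`) gives 10.8% as the only number so far. Compound 4 (`CC(=O)SCCC(CCCCC(=O)Nc1ccccc1Cl)SC(C)=O`) is still unmeasured. Its structural change is (2-chlorophenyl)amino in place of hydroxy on a carbonyl carbon with (2-chlorophenyl)amino in place of hydroxy on a carbonyl carbon. Within the data shown here, no measured step guides the expectation, so only a small rise in growth inhibition is expected in this assay from this change. Compound 3 at 10.8% supports that expectation, while compound 2 at "not active" (no number reported) goes against it. For compound 4 the expected value is 12% (estimated range 2% to 30%).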

Compound 4, percent growth inhibition at one concentration: 2.48%
The estimate for compound 4 lay 9.5 percentage points above the measured number, and the stated range covers the measured number.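

Within the data shown here, compound 1 is recorded only as "not active", without a number, so no step to compound 4 can be read. The compounds shown leave open whether (2-chlorophenyl)amino in place of hydroxy changes growth inhibition. No available evidence bears on this result.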